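The compounds below may be only part of what the source reports. "The series", "measured", "known", "first", "only" and "open" are said of these compounds alone.

Compound 1 `Oc1ccccc1-c1cc(-c2ccccc2F)cc(-c2ccccc2O)n1` carries two 2-hydroxyphenyl groups and a 2-fluorophenyl group on a shared core. In a functional assay on HeLa cells (Homo sapiens) for inhibition (a lower number here means a stronger inhibitor, a higher number a weaker inhibitor), compound 1 gives only a limit, > 50000 nM. Compound 2 `Oc1ccccc1-c1cc(-c2cccc(F)c2)cc(-c2ccccc2O)n1` differs from it by 3-fluorophenyl in place of 2-fluorophenyl on an aromatic carbon. In this assay compound 2 likewise gives only a limit, > 50000 nM. The step from compound 1 to compound 2 is therefore a step that the two limits leave unreadable from compound 1 to compound 2. Compound 3 `Oc1ccc(-c2cc(-c3ccccc3F)cc(-c3ccccc3O)n2)cc1` differs from compound 1 by 4-hydroxyphenyl in place of 2-hydroxyphenyl on an aromatic carbon. In this assay compound 3 also gives only a limit, > 50000 nM. So the step from compound 1 to compound 3 is a step that the two limits leave unreadable from compound 1 to compound 3, and all three values share (the limit of > 50000 nM in this assay, at which 3 of the 3 values shown sit).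

Compound 4 `Oc1ccc(-c2cc(-c3cccc(F)c3)cc(-c3ccccc3O)n2)cc1` is not yet measured; it differs from compound 3 by 3-fluorophenyl in place of 2-fluorophenyl on an aromatic carbon. This is the same kind of change as from compound 1 to compound 2, though here the place is meta to a 2-hydroxyphenyl group and a 4-hydroxyphenyl group rather than to two 2-hydroxyphenyl groups. The step from compound 3 to compound 4 is expected to be a step that the limit leaves unreadable from compound 3 to compound 4, resting on the unreadable step from compound 1 to compound 2, a step that the two limits leave unreadable from compound 1 to compound 2. Compound 4 is thus estimated at 80000 nM, most likely again only a limit, with a range from 30000 nM to 300000 nM.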

Compound 4, half-maximal inhibitory concentration: > 50000 nM
Compound 4: no number, only a limit (the forecaster's own chance of this, stated with the estimate: 85%); the middle value lies beyond the limit too.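

Compound 4 also gives only a limit in this assay, so neither the step from compound 3 to compound 4 nor the step from compound 2 to compound 4 can be read, and the compounds all end at the same limit: the limit of > 50000 nM in this assay, at which 4 of the 4 values shown sit.

The compounds shown leave open whether 3-fluorophenyl in place of 2-fluorophenyl, or 4-hydroxyphenyl in place of 2-hydroxyphenyl, changes inhibition at all.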